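Swapping Acetoxy for Ethoxy on the Shared Core

This account rests on a few compounds, and the source may have more. Where it says the series, first, only, none or still open, it means among the compounds named here.

In a functional assay on DA-3 cells for cytotoxicity against DA-3 cell line (Mus musculus), read by MTT assay (on this read-out lower numbers stand for stronger inhibition and higher numbers for weaker inhibition), compound 1 `CC(=O)O[C@@H]1OC(=O)[C@](C)(C(C)=O)[C@@H]1C` gives 7000 nM as its half-maximal inhibitory concentration. Compound 3 `CC(=O)O[C@@H]1OC(=O)[C@](Br)(C(C)=O)[C@@H]1C` gives 6000 nM in this assay and a 1.2-fold lower number from compound 1 to compound 3 (0.07 log units; within the scatter) leaves the two level with each other. Compound 2 `CC(=O)O[C@@H]1OC(=O)[C@](O)(C(C)=O)[C@@H]1C` gives > 50000 nM as its result, which is a limit of the assay and not a number. Compound 1 therefore stands level with compound 3 and on the stronger side of compound 2.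

Compound 4 `CCO[C@@H]1OC(=O)[C@](C)(C(C)=O)[C@@H]1C` keeps the core of compound 1 but alters a different place: ethyl in place of acetyl on an oxygen on a saturated carbon gives ethyl in place of acetyl on an oxygen on a saturated carbon, turning acetoxy into ethoxy. Among the measured compounds shown here, all three measured compounds carry the acetoxy group, so no measured step tests this swap directly. Their changes fall on a saturated ring carbon and show only how far one change can move the number. Compound 3 barely moved, whereas an at least 7.1-fold higher number from compound 1 to compound 2 (0.85 log units; beyond the scatter) shows a clear loss after a single change. Going by compound 2, a modest rise is expected rather than a fall. The estimated size is a 2.1-fold higher number from compound 1 to compound 4 (0.33 log units; beyond the scatter) with wide uncertainty. For compound 4 the expected value is 15000 nM with 5000 nM to 45000 nM as its estimated range.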

Compound 4, half-maximal inhibitory concentration: > 50000 nM
Compound 4 ended at the assay's limit; the forecaster's own chance of this, stated with the estimate: 20%; middle value at least 3.3-fold (0.52 log units) from the limit.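

The acetoxy group on the shared core turns out to matter in this assay: putting ethyl in place of acetyl on an oxygen on a saturated carbon gives an at least 7.1-fold higher number from compound 1 to compound 4 (0.85 log units; beyond the scatter). Among the compounds shown here, until now, every measured change sat on a saturated ring carbon, so this is the first sign that the group on this oxygen also affects the result, with acetyl carrying a hydrogen-bond acceptor and a double bond that ethyl lacks. From the compounds shown here alone, for compound 4 the result is a limit of the assay and not a number, so the full size of the loss stays unknown and compound 4 cannot be placed in order against compound 2, which ends at the same limit: the limit of > 50000 nM in this assay, at which 2 of the 4 values shown sit.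

The compounds shown do not reveal whether keeping a carbonyl on this oxygen is enough to hold the number, as a propanoyl or benzoyl group in place of acetyl could test, or whether a longer chain such as propyl would fare any differently from ethyl. Going by these compounds, it also stays open whether the same swap would cost as much on compound 3, which carries bromo on the saturated ring carbon.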